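Capping the Phenol: From Compound 3 to Compound 4

The source may hold more compounds than are shown below. What is called first, only, known or untested is meant among the compounds shown, and "the series" means these compounds.

Measured in an assay on isolated protein for inhibition of Indoleamine 2,3-dioxygenase 1 (Homo sapiens), read by spectrophotometry; on this read-out lower numbers stand for stronger inhibition and higher numbers for weaker inhibition:
Compound 1 `O=C(Cc1cccnc1)c1cc2cc(Cl)ccc2[nH]1` gives 24600 nM.
Compound 2 `O=C(Cc1cccnc1)c1cc2cc(Br)ccc2[nH]1` gives 18000 nM.
Compound 3 `O=C(Cc1cccnc1)c1cc2cc(O)ccc2[nH]1` gives 37000 nM.

Compound 3 stands highest of the three numbers, with a step of a 2.1-fold higher number from compound 2 to compound 3 (0.31 log units; beyond the scatter) and of a 1.5-fold higher number from compound 1 to compound 3 (0.18 log units; within the scatter), so the hydroxy analogue is at the weak end of this small set. Compound 4 `COc1ccc2[nH]c(C(=O)Cc3cccnc3)cc2c1` differs from compound 3 by methyl in place of hydrogen on an oxygen on an aromatic ring. Within the data shown here, no measured step touches the oxygen itself; the two steps that bear on this position swap whole groups rather than cap one, and both are modest. The expectation is therefore a step of a 1.2-fold lower number from compound 3 to compound 4 (0.09 log units; within the scatter) in this assay, not beyond the scatter. Compound 4 is estimated at 30000 nM, between 12000 nM and 75000 nM.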

Compound 4, half-maximal inhibitory concentration: 49000 nM
Compound 4: the middle estimate sits 1.6-fold (0.21 log units) below what was measured; the range from low to high includes it.
By their numbers in this assay, from the lowest: compounds 2, 1, 3 and 4 (each within the scatter of the next, the first and the last beyond it).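

In this assay the step of a 1.3-fold higher number from compound 3 to compound 4 (0.12 log units; within the scatter) stays within the scatter, so capping the hydroxy oxygen with methyl is not shown to change the number at this position. Set against the halogen compounds, the methoxy group gives a split picture: a 2.0-fold higher number from compound 1 to compound 4 (0.30 log units; within the scatter) is within the scatter, while a 2.7-fold higher number from compound 2 to compound 4 (0.43 log units; beyond the scatter) lies modestly beyond it. No evidence on the reason for these numbers is available. Still open, going by these compounds, is whether an amine or a carboxylic acid at this position, or a longer chain on the oxygen, would move the number further.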